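Extending the Hydroxyalkyl Ether Chain of Compound 3

This account rests on a few compounds, and the source may have more. Where it says the series, first, only, none or still open, it means among the compounds named here.

Of the compounds shown here, three sharing one core have been measured in a functional assay on DU-145 cells (Homo sapiens) for cytotoxicity, read by MTT assay; on this read-out lower numbers stand for stronger inhibition and higher numbers for weaker inhibition. Compound 1 `CC(C)=CC[C@@H](OC(=O)c1ccoc1)C1=CC(=O)c2c(O)ccc(O)c2C1=O` gives only a limit in this assay, > 100000 nM; this is the limit (the limit of > 100000 nM in this assay, at which 1 of the 3 values shown sits). Compound 2 `CCCCC(C)(O)CC(=O)O[C@H](CC=C(C)C)C1=CC(=O)c2c(O)ccc(O)c2C1=O` gives 76500 nM in this assay, and compound 3 `CC(C)=CC[C@@H](OCCO)C1=CC(=O)c2c(O)ccc(O)c2C1=O` gives 9900 nM. Compound 3 has the lowest of the two numbers, its nearest neighbour being compound 2, described by the step of a 7.7-fold lower number from compound 2 to compound 3 (0.89 log units; beyond the scatter); from the ester compound 1 the step is an at least 10-fold lower number from compound 1 to compound 3 (1.00 log units; beyond the scatter), and between the two esters it is an at least 1.3-fold lower number from compound 1 to compound 2 (0.11 log units; that floor lies within the scatter).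

Compound 4 `CCC(O)CO[C@H](CC=C(C)C)C1=CC(=O)c2c(O)ccc(O)c2C1=O` differs from compound 3 by ethyl in place of hydrogen on a saturated chain carbon bound to an oxygen on a saturated carbon and a saturated chain carbon. For the measured compounds named here, none of the measured steps touches this chain carbon: two of them swap an ester for the 2-hydroxyethyl ether, and the third swaps one acyl group for another. So a 7.7-fold lower number from compound 2 to compound 3 (0.89 log units; beyond the scatter) and an at least 10-fold lower number from compound 1 to compound 3 (1.00 log units; beyond the scatter) speak to a different part of the molecule and do not directly predict what an added ethyl will do. Without a direct guide, the step expected for compound 4, a 1.1-fold lower number from compound 3 to compound 4 (0.04 log units; within the scatter), is small and within the scatter. Compound 4 is therefore estimated at 9000 nM, with a range from 3000 nM to 30000 nM.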

Compound 4, half-maximal inhibitory concentration: 16400 nM
For compound 4 the middle estimate is 1.8-fold (0.26 log units) below the measured one; the measured number falls inside the stated range.
By their numbers in this assay, from the lowest: compounds 3 and 4 (each within the scatter of the next); then compound 2. At a limit, above all of these: compound 1.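

Adding an ethyl to this saturated chain carbon, which turns 2-hydroxyethyl into 2-hydroxybutyl, gives the first measured change at this position in this assay, and the result is a 1.7-fold higher number from compound 3 to compound 4 (0.22 log units; within the scatter), so the two ethers cannot be told apart here. The lower numbers seen for the ether against the ester also hold with the longer chain, with a 4.7-fold lower number from compound 2 to compound 4 (0.67 log units; beyond the scatter). Compound 1 gives only a limit, so the step to the other ether, an at least 6.0-fold lower number from compound 1 to compound 4 (0.78 log units; beyond the scatter), is a floor and not a measured size: the limit of > 100000 nM in this assay, at which 1 of the 4 values shown sits.

With a single pair of ethers, no trend with chain length can be claimed. Going by these compounds, it remains open whether a longer chain, or an amine or a carboxylic acid on the ether chain, would shift the number beyond the scatter.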